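Swapping the aryl ketone in a trimethoxyphenyl triazolothiadiazine series

The source may report more compounds than this note shows. Statements on the series, on what has been measured and on what is new or still open speak of the compounds shown alone.

Of the compounds shown here, three sharing one core have been tested in a functional assay on PC-3 cells (Homo sapiens) for cytotoxicity, read by MTT assay, with a stated time of 48 h; a higher number here means a weaker inhibitor, a lower number a stronger inhibitor. Compound 1 `COc1cc(-c2nnc3n2NC(c2ccco2)C(C(=O)c2ccc(Cl)cc2)S3)cc(OC)c1OC` gives 67800 nM, compound 3 `COc1cc(-c2nnc3n2NC(c2ccco2)C(C(=O)C2CC2)S3)cc(OC)c1OC` gives 95200 nM, and the step of a 1.4-fold higher number from compound 1 to compound 3 (0.15 log units; within the scatter) shows that changing the group on the carbonyl carbon barely moved the number. Compound 2 `COc1cc(-c2nnc3n2NC(c2cccs2)C(C(=O)c2ccc(C)cc2)S3)cc(OC)c1OC` gives 5090 nM, the lowest of the three, with compound 1 giving a higher number and compound 3 the highest of the three. Compound 4 `COc1cc(C(=O)C2Sc3nnc(-c4cc(OC)c(OC)c(OC)c4)n3NC2c2cccs2)cc(OC)c1OC` differs from compound 2 by 3,4,5-trimethoxyphenyl in place of 4-methylphenyl on a carbonyl carbon. Going by the values given here, only the step from compound 1 to compound 3 touches the same position, and it lay within the scatter, so no direction can be inferred. Compound 4 is therefore expected to give roughly 9000 nM (range 2500 nM to 40000 nM), a step of a 1.8-fold higher number from compound 2 to compound 4 (0.25 log units; within the scatter) from compound 2 in this assay, estimated with little confidence.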

Compound 4, half-maximal inhibitory concentration: > 100000 nM
Compound 4 ended at the assay's limit; the forecaster's own chance of this, stated with the estimate: 5%; middle value at least 11-fold (1.04 log units) away from the limit.
By their numbers in this assay, from the lowest: compound 2; then compounds 1 and 3 (each within the scatter of the next). At a limit, above all of these: compound 4.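

In this assay, 3,4,5-trimethoxyphenyl in place of 4-methylphenyl on the carbonyl carbon gives an at least 19-fold higher number from compound 2 to compound 4 (1.29 log units; beyond the scatter) and so shows that this position can move the result, which a 1.4-fold higher number from compound 1 to compound 3 (0.15 log units; within the scatter) did not show. The value of compound 4 is a limit of the assay, not a number: the limit of > 100000 nM in this assay, at which 1 of the 4 values shown sits. This rests on a single pair, so it sets no pattern for other groups here.

On these data alone, how far compound 4 lies past its limit stays open. Also open, as far as these compounds go, is whether 4-methoxyphenyl or 4-aminophenyl on the carbonyl carbon would stay near compound 2 or move towards compound 4.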